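The source may hold more compounds than are shown below. What is called first, only, known or untested is meant among the compounds shown, and "the series" means these compounds.

Compounds measured in a functional assay on CHO cells for agonist activity at metabotropic glutamate receptor 5 (Homo sapiens), read by inositol phosphate accumulation; a higher number here means a weaker inhibitor, a lower number a stronger inhibitor:
compound 1 `COc1cccc(C#Cc2csc(C)n2)c1` gives 49 nM
compound 2 `Cc1nc(C#Cc2cccc(C(F)(F)F)c2)cs1` gives 413 nM
compound 3 `Cc1nc(C#Cc2cccc(OC(F)(F)F)c2)cs1` gives 266 nM

Compound 3 stands second highest of the three numbers. Its nearest neighbour is compound 2, a step of a 1.6-fold lower number from compound 2 to compound 3 (0.19 log units; within the scatter) that stays within the scatter, so no order between the two can be read. Its furthest is compound 1, with a 5.4-fold higher number from compound 1 to compound 3 (0.73 log units; beyond the scatter).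

Compound 4 `Cc1nc(C#Cc2cccc(C#N)c2)cs1` differs from compound 3 by cyano in place of trifluoromethoxy on an aromatic carbon. Within the data shown here, no measured step replaces a group on this aromatic carbon with cyano, so the bearing of the existing steps is indirect. What the three compounds show is that a swap at this position can move this assay by more than the scatter: an 8.4-fold higher number from compound 1 to compound 2 (0.93 log units; beyond the scatter) and a 5.4-fold higher number from compound 1 to compound 3 (0.73 log units; beyond the scatter) both went to higher numbers from compound 1, while a 1.6-fold lower number from compound 2 to compound 3 (0.19 log units; within the scatter) stayed flat. A step to cyano can thus be beyond the scatter in either direction, and the direction is not settled by the data. Taking the span of the series as the guide, compound 4 is expected near the middle of the measured range, which corresponds to a step of a 2.2-fold lower number from compound 3 to compound 4 (0.35 log units; beyond the scatter) estimated from compound 3. The estimate for compound 4 is 120 nM, with a range from 25 nM to 600 nM.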

Compound 4, half-maximal inhibitory concentration: 0.94 nM
Compound 4: the middle estimate sits 130-fold (2.11 log units) above what was measured; measured number outside the range, below it.
By their numbers in this assay, from the lowest: compound 4; then compound 1; then compounds 3 and 2 (each within the scatter of the next).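

In this assay, the change to cyano moves the number far more than any earlier change at this position, with a 280-fold lower number from compound 3 to compound 4 (2.45 log units; beyond the scatter) and a 440-fold lower number from compound 2 to compound 4 (2.64 log units; beyond the scatter) against the two fluorinated groups and a 52-fold lower number from compound 1 to compound 4 (1.72 log units; beyond the scatter) against methoxy, which makes compound 4 the strongest inhibitor of the four. Methoxy therefore no longer marks the low end of the series, and the earlier compounds gave no sign that a group on this aromatic carbon could reach so far. Cyano is smaller by count than trifluoromethoxy, with 2 heavy atoms against 5, while each has 1 hydrogen-bond acceptor, but no measurement shown accounts for the size of this step.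

The compounds shown leave open whether this gain is particular to cyano or extends to a chlorine atom, an acetyl group or a primary amide on this aromatic carbon. They also leave open whether it carries over when the methyl group on the shared core gives way to a longer chain such as ethyl.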